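Working notes: trifluoromethyl to trifluoromethoxy in one series

The source may report more compounds than this note shows. Statements on the series, on what has been measured and on what is new or still open speak of the compounds shown alone.

Measured in an ADME assay for permeability, using PAMPA, in phosphate buffer, with a stated time of 18 h, tested at 25 ug/mL (a higher number here means that the compound crosses the layer faster, a lower number that the compound crosses the layer more slowly), so far:
- compound 1 `O=C(N/N=C/c1ccc(Br)cc1)N1CCN(c2ccccn2)CC1` gives 3.6 10^-6 cm/s on the shared read-out
- compound 2 `FC(F)(F)c1ccc(-c2nnc(N3CCN(c4ccccn4)CC3)o2)cc1` gives 6.3 10^-6 cm/s on the shared read-out

Compound 2 stands level with compound 1 on these numbers, as the two values lie within the usual scatter of each other. Among the measured compounds shown here, no measured pair differs in one place only, so the data offer no direct guide to the size of a single change.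

Compound 3 `FC(F)(F)Oc1ccc(-c2nnc(N3CCN(c4ccccn4)CC3)o2)cc1` has not yet been measured. Its change from compound 2 is trifluoromethoxy in place of trifluoromethyl on an aromatic carbon with trifluoromethoxy in place of trifluoromethyl on an aromatic carbon, para to a large group. The rest of the structure stays the same.

With compound 2 at 6.3 10^-6 cm/s as the closest measured reference, no step beyond the scatter is expected in this assay for this replacement. The expected move is a 1.0-fold higher number from compound 2 to compound 3 (0.01 log units; within the scatter) and it is estimated to stay within the scatter. Compound 3 is estimated at 6.5 10^-6 cm/s with an expected range of 2.8 10^-6 cm/s to 13 10^-6 cm/s for the coming measurement.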

Compound 3, apparent permeability: 6.8 10^-6 cm/s
For compound 3 the middle estimate is 1.0-fold (0.02 log units) below the measured one; low and high end bracket the measured number.
By their numbers in this assay, from the lowest: compounds 1, 2 and 3 (each within the scatter of the next).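

In this assay the series now holds its first pair that differs in one place only, which gives a direct reading of a single change. Trifluoromethoxy in place of trifluoromethyl on an aromatic carbon, para to a large group, comes with a 1.1-fold higher number from compound 2 to compound 3 (0.03 log units; within the scatter) and so stays within the scatter, even though the entering group brings an oxygen and one hydrogen-bond acceptor by count. At this position and on this shared core, the two groups can therefore be treated as level on this read-out, and nothing in hand bears on the reason for that result.

Going by these compounds, it remains open whether other groups at the same position, such as a nitrile, an amine, a carboxylic acid or a longer alkyl chain, would also stay within the scatter of compound 2. This single pair also cannot show whether the same replacement would give a similar step at another place on the aromatic ring or on a different core, such as that of compound 1.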